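Trading a Methylsulfonyl Ring for a Sulfamoyl Ring

The compounds below may be only part of what the source reports. "The series", "measured", "known", "first", "only" and "open" are said of these compounds alone.

Measured so far, in an assay for binding affinity to dual specificity mitogen-activated protein kinase kinase 4 (Homo sapiens), read by KINOMEscan, tested at 100 nM; a higher number here means a weaker effect of the compound at the concentration tested, a lower number a stronger effect:
- compound 1 `CCCS(=O)(=O)Nc1ccc(F)c(C(=O)c2n[nH]c3ncc(-c4ccccc4C)cc23)c1F` gives 7%
- compound 2 `CCCS(=O)(=O)Nc1ccc(F)c(C(=O)c2n[nH]c3ncc(-c4ccc(Cl)cc4Cl)cc23)c1F` gives 22%
- compound 3 `CCCS(=O)(=O)Nc1ccc(F)c(C(=O)c2n[nH]c3ncc(-c4ccc(S(C)(=O)=O)cc4)cc23)c1F` gives 1.5%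

Compound 3 has the lowest number of the three, which in this assay means the strongest effect at the concentration tested. Its nearest neighbour is compound 1, a pair whose gap lies within the scatter (a number 5.5 percentage points lower from compound 1 to compound 3 (within the scatter)), while compound 2 stands furthest away (a number 20.5 percentage points lower from compound 2 to compound 3 (beyond the scatter)).

The next compound, compound 4 `CCCS(=O)(=O)Nc1ccc(F)c(C(=O)c2n[nH]c3ncc(-c4ccc(S(N)(=O)=O)cc4C)cc23)c1F`, differs from compound 3 in one place: 2-methyl-4-sulfamoylphenyl in place of 4-(methylsulfonyl)phenyl on an aromatic carbon. The entering group keeps a sulfur-bearing substituent on the ring and adds the 2-methyl that compound 1 already carries. Among the compounds with values here, the step that bears most on this is the one from compound 1 to compound 3, which stayed within the scatter; only the 2,4-dichlorophenyl of compound 2 moved the number clearly. The expected step for compound 4 is therefore small, a number 2.5 percentage points higher from compound 3 to compound 4 (within the scatter), and not beyond the scatter. Compound 4 is estimated at 4%, with a range from 1% to 12%.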

Compound 4, a percentage reported as activity, at one concentration (the size of the read-out at that concentration, not a potency): 3.1%
Estimate against measurement, compound 4: 0.9 percentage points above; the range from low to high includes it.
By their numbers in this assay, from the lowest: compounds 3, 4 and 1 (each within the scatter of the next); then compound 2.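

At this position the ring tolerates a sulfamoyl group in this assay: adding it to the 2-methylphenyl ring gives a number 3.9 percentage points lower from compound 1 to compound 4 (within the scatter), and replacing the whole 4-(methylsulfonyl)phenyl group gives a number 1.6 percentage points higher from compound 3 to compound 4 (within the scatter), so neither change separates from the usual spread of repeat measurements. The 2,4-dichlorophenyl group remains the one clear outlier among these rings, with a number 18.9 percentage points lower from compound 2 to compound 4 (beyond the scatter), which shows that the sulfamoyl ring behaves like the other two rings and not like the dichloro ring. No measurement here explains why these rings read alike.

The 2-methyl and sulfamoyl groups entered together in the step from the methylsulfonyl ring, so the effect of each alone remains unresolved. On these data alone, it also remains open whether a carboxylic acid or an amine in place of the sulfamoyl group would keep the number as low.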